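The source may hold more compounds than are shown below. What is called first, only, known or untested is meant among the compounds shown, and "the series" means these compounds.

Compound 1, with the structure `c1ccc(N2CCN(CCCCOc3ccc4c(c3)CCC4)CC2)cc1`, is the reference point of this small set. In a functional assay on the whole organism for inhibition, with Mus musculus as the target, at a dose of 25 mg/kg by the oral route (a lower number here means less inhibition, a higher number more inhibition at the dose given (going by the name of the read-out)), compound 1 gives 75%. Compound 2, `c1ccc(N2CCN(CCCOc3cccc4c3CCC4)CC2)cc1`, is built on a different core; how its core differs from that of compound 1 is not broken down here. In this assay compound 2 gives 0%. Compound 3, `Fc1ccc(N2CCN(CCCOc3cccc4c3CCC4)CC2)cc1`, shares the core of compound 2 and carries the change (fluoro in place of hydrogen on an aromatic carbon), where the fluoro sits para to a large group on a six-membered aromatic ring of carbon only. In this assay compound 3 gives 5%, so the step of a number 5 percentage points higher from compound 2 to compound 3 (within the scatter) is small. Compound 1 stands well apart from both: its number is higher than that of compound 3 and of compound 2 by margins that lie beyond the scatter.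

Compound 4, `Fc1cc2c(cc1OCCCCN1CCN(c3ccccc3)CC1)CCC2`, has not been measured. It differs from compound 1 by fluoro in place of hydrogen on an aromatic carbon. Going by the values given here, this is the same kind of change as the one from compound 2 to compound 3, but not the same: here the fluoro enters on a ring that is part of a fused or bridged system of two rings, ortho to a large group, meta to a fused ring and para to a fused ring, rather than para to a large group on a lone ring. Among the compounds with values here, because the only measured instance of this kind of change, a number 5 percentage points higher from compound 2 to compound 3 (within the scatter), stayed within the scatter, the account expects a similarly small step a number 5 percentage points lower from compound 1 to compound 4 (within the scatter) for compound 4, resting on the value of compound 1, 75%. The estimate for compound 4 in this assay is therefore 70%, expected to fall between 45% and 90%.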

Compound 4, a percentage reported as inhibition, in the whole organism at one dose (the size of the read-out at that dose, not a potency): 33%
Compound 4: middle estimate off by 37 percentage points, on the high side; measured number below the stated range.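

In this assay, the change of fluoro in place of hydrogen on an aromatic carbon does not carry from one core to the other in this series: the same change on two cores in this assay, a number 5 percentage points higher (within the scatter) from compound 2 to compound 3 and a number 42 percentage points lower (beyond the scatter) from compound 1 to compound 4, 47 percentage points apart, beyond the scatter of two such steps On the core of compound 1 the change gives the large step, a number 42 percentage points lower from compound 1 to compound 4 (beyond the scatter), so the small step seen on the other core gave no reliable guide to it. What these two steps do not show is why they part, since the cores differ and the fluoro also sits in a different place, on a lone ring in compound 3 and on a ring of a fused system in compound 4, and two pairs at one dose cannot separate these two differences.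

The compounds shown leave open whether the fall belongs to this particular place, or whether fluoro on the lone ring of compound 1, as in compound 3, would lower the number as well. They also leave open whether chloro or a methyl group, entering at the same place as the fluoro of compound 4, would give a step of similar size, or whether the step belongs to fluoro alone.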